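The source may report more compounds than this note shows. Statements on the series, on what has been measured and on what is new or still open speak of the compounds shown alone.

Of the compounds shown here, three share the same dimethylurea unit and have been tested in a functional assay on K562 cells (Homo sapiens) for antiproliferative activity, read by MTT assay, with a stated time of 48 h; a lower number here means a stronger inhibitor, a higher number a weaker inhibitor. Compound 1 `CCOC(=O)N1CCC(N(Cc2cccc([N+](=O)[O-])c2)C(=O)N(C)C)CC1` gives 26000 nM. Compound 2 `CN(C)C(=O)N(Cc1ccc(O)cc1)Cc1ccco1` gives 18600 nM, and compound 3 `CN(C)C(=O)N(Cc1ccco1)Cc1cc([N+](=O)[O-])ccc1O` gives 28600 nM. Compound 1 sits between the other two numbers, but its gap to compound 3 and its gap to compound 2 both fall within the usual scatter of repeated measurements, so the three values cannot be told apart with confidence.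

Compound 4 `CCOC(=O)N1CCC(N(Cc2cc(Br)ccc2O)C(=O)N(C)C)CC1` has not yet been measured. It differs from compound 1 in one place: 5-bromo-2-hydroxyphenyl in place of 3-nitrophenyl on a saturated chain carbon bound to an amide-type nitrogen. Going by the values given here, no measured pair shows the effect of this exchange on its own, so the expectation rests on the spread of the three numbers seen so far, which is narrow. Because compound 2 gives 18600 nM and compound 3 gives 28600 nM with a hydroxyphenyl group of their own, no step beyond the scatter is expected. Compound 4 is expected to give 25000 nM, with a likely range from 9000 nM to 70000 nM. The expected change is a 1.0-fold lower number from compound 1 to compound 4 (0.02 log units; within the scatter).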

Compound 4, half-maximal inhibitory concentration: 41800 nM
Compound 4: the middle estimate sits 1.7-fold (0.22 log units) below what was measured, and the stated range covers the measured number.
By their numbers in this assay, from the lowest: compounds 2, 1, 3 and 4 (each within the scatter of the next, the first and the last beyond it).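

Putting 5-bromo-2-hydroxyphenyl in place of 3-nitrophenyl on a saturated chain carbon bound to an amide-type nitrogen gives a 1.6-fold higher number from compound 1 to compound 4 (0.21 log units; within the scatter) in this assay. This is the first pair shown that differs in one place, and it indicates that this site accepts a quite different substituted phenyl without a step that can be told from repeat-measurement noise. The exchange removes the nitro group and brings in the hydroxyl and the bromine together, and no measurement shown here offers a reason for the result.

From the compounds shown here alone, it remains open whether the hydroxyl and the bromine each matter when present alone. How an unsubstituted phenyl, or a phenyl carrying an amine or a carboxylic acid, would read at this site is also unknown from these compounds.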